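The source may report more compounds than this note shows. Statements on the series, on what has been measured and on what is new or still open speak of the compounds shown alone.

Measured compounds in a functional assay on CFPAC-1 cells (Homo sapiens) for inhibition, read by MTT assay, with a stated time of 72 h; on this read-out lower numbers stand for stronger inhibition and higher numbers for weaker inhibition:
Compound 1 `O=c1cc(Cn2cc(CCCCO)nn2)c2ccc(O)cc2o1` gives > 100000 nM, which is a limit of this assay.
Compound 2 `CC(C)(C)c1cn(Cc2cc(=O)oc3cc(O)ccc23)nn1` gives > 100000 nM, also a limit of this assay.
Compound 3 `O=c1cc(Cn2cc(-c3ccc(Br)cc3)nn2)c2ccc(O)cc2o1` gives 52900 nM.

Compound 1 stands at the limit, as stated by the limit of > 100000 nM in this assay, at which 2 of the 3 values shown sit, so no number is known for it in this assay. The step to compound 2, a step that the two limits leave unreadable from compound 1 to compound 2, cannot be read from those two limits. The step of an at least 1.8-fold lower number from compound 1 to compound 3 (0.27 log units; that floor lies within the scatter) gives only a floor, and an at least 1.8-fold lower number from compound 2 to compound 3 (0.27 log units; that floor lies within the scatter) gives the same kind of floor, each within the scatter.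

Compound 4 `O=c1cc(Cn2cc(CSC(=S)N3CCNCC3)nn2)c2ccc(O)cc2o1` is not yet measured in this assay. It differs from compound 1 by a group of 9 heavy atoms (5 carbon, 2 nitrogen, 2 sulfur; one six-membered non-aromatic ring with 2 hetero atoms) in place of a group of 4 heavy atoms (3 carbon, 1 oxygen; no ring), on a saturated chain carbon bound to an aromatic carbon. Going by the values given here, none of the measured steps changes the same kind of group at the same place, so they bear on the step from compound 1 to compound 4 only loosely: they show that a larger ring-bearing group can bring the number down from the limit, as with compound 3, but not by much beyond the scatter.

For compound 4 the step of an at least 1.6-fold lower number from compound 1 to compound 4 (0.22 log units; that floor lies within the scatter) is therefore expected to be small and uncertain in direction. Compound 4 is estimated at 60000 nM, with a range from 15000 nM to 250000 nM in this assay.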

Compound 4, half-maximal inhibitory concentration: > 100000 nM
Compound 4 ended at the assay's limit; the forecaster's own chance of this, stated with the estimate: 50%; at least 1.6-fold (0.22 log units) between middle value and limit.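

In this assay compound 4 gives > 100000 nM, which is a limit of the assay and not a number. Compound 1 also stands at a limit, so no step from compound 1 to compound 4 can be read, and compound 4 joins the compounds at that limit: the limit of > 100000 nM in this assay, at which 3 of the 4 values shown sit.

The compounds shown leave open whether compound 1, compound 2 and compound 4 differ from one another at all in this assay.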